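Swapping an aromatic ring for a methyl group

The compounds below may be only part of what the source reports. "The series", "measured", "known", "first", "only" and "open" are said of these compounds alone.

In a functional assay on the whole organism for inhibition, with Felis catus as the target, with a stated time of 30 min (a lower number here means that less compound is needed, a higher number that more compound is needed for the effect), compound 1 `OC(CNCCOc1ccccc1)COc1ccccc1` gives 0.054 mg/kg. Compound 2 `OC(CNCCOc1cccc(Cl)c1)COc1ccccc1` gives 0.375 mg/kg and compound 3 `OC(CNCCOc1ccccc1)COc1ccccc1Br` gives 0.3 mg/kg. These two values lie within the scatter of each other, and both are clearly higher than the value of compound 1. Compound 4 `COCCNCC(O)COc1ccccc1` is still unmeasured. Compared with compound 2 it has methyl in place of 3-chlorophenyl on an oxygen on a saturated carbon. The measured steps are smaller changes: chloro in place of hydrogen gave a 6.9-fold higher number from compound 1 to compound 2 (0.84 log units; beyond the scatter), and bromo in place of hydrogen gave a 5.6-fold higher number from compound 1 to compound 3 (0.74 log units; beyond the scatter). Neither removes a ring, so they guide only loosely, but a change this large is expected to raise the number further. The expected step is a 4.0-fold higher number from compound 2 to compound 4 (0.60 log units; beyond the scatter). For compound 4 the estimated value is 1.5 mg/kg, with a range of 0.3 mg/kg to 8 mg/kg.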

Compound 4, dose for half-maximal effect: 0.13 mg/kg
Compound 4: middle estimate off by 12-fold (1.06 log units), on the high side; measured number below the stated range.
By their numbers in this assay, from the lowest: compound 1; then compound 4; then compounds 3 and 2 (each within the scatter of the next).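

Replacing the ring with a small group does not have one fixed effect at this oxygen in this assay. Methyl in place of 3-chlorophenyl gives a 2.9-fold lower number from compound 2 to compound 4 (0.46 log units; beyond the scatter), whereas methyl in place of phenyl gives a 2.4-fold higher number from compound 1 to compound 4 (0.38 log units; beyond the scatter), so the direction depends on which ring leaves. The aromatic ring at this place is therefore not required for a measurable effect, though the unsubstituted phenyl gives the lowest number here, and no measurement shown explains this. The compounds shown leave open how ethyl, a longer chain or cyclohexyl on this oxygen would compare with methyl and phenyl.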